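Single Stereocentre Flip After Two Weak Diastereomers

A few compounds are considered here, and "the series" means these few. Any claim that something is new, unique, unknown or untested is made for them only; others in the source may bear on it.

Measured so far:
compound 1 `Cc1ccc(/C=C/[C@]2(C)CC[C@@](C)(/C=C/C3=C[C@H](O)[C@](C)(O)C[C@@H]3O)O2)cc1` — > 50000 nM
compound 2 `Cc1ccc(/C=C/[C@@]2(C)CC[C@](C)(/C=C/C3=C[C@H](O)[C@](C)(O)C[C@@H]3O)O2)cc1` — 31100 nM

In a functional assay on HepG2 cells (Homo sapiens) for inhibition, read by MTT assay, with a stated time of 72 h (on this read-out lower numbers stand for stronger inhibition and higher numbers for weaker inhibition), compound 1 gives > 50000 nM, which is a limit of the assay rather than a number. Compound 2 gives 31100 nM, the only number shown. For the measured compounds named here, the single step measured, an at least 1.6-fold lower number from compound 1 to compound 2 (0.20 log units; that floor lies within the scatter), rests on the fact that compounds 1 and 2 differ only in the configuration as drawn and on (the limit of > 50000 nM in this assay, at which 1 of the 2 values shown sits), and it lies within the scatter. Compound 3 `Cc1ccc(/C=C/[C@@]2(C)CC[C@@](C)(/C=C/C3=C[C@H](O)[C@](C)(O)C[C@@H]3O)O2)cc1` is not yet measured; it differs from compound 2 thus: the two compounds have the same atoms and bonds and differ only in configuration as drawn: 1 of 7 stereo elements differ; a stereocentre at a saturated ring carbon is drawn R in compound 2 and S in compound 3. A stereochemical change of this kind has so far moved the read-out little, so no step beyond the scatter is expected. For compound 3 the estimate is 35000 nM, ranging from 12000 nM to 100000 nM. The expected step is a 1.1-fold higher number from compound 2 to compound 3 (0.05 log units; within the scatter).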

Compound 3, half-maximal inhibitory concentration: > 50000 nM
Compound 3: no number, only a limit (the forecaster's own chance of this, stated with the estimate: 40%); middle value at least 1.4-fold (0.15 log units) away from the limit.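

Changing one stereocentre at a saturated ring carbon alone, from R to S, gives an at least 1.6-fold higher number from compound 2 to compound 3 (0.20 log units; that floor lies within the scatter) and so, in this assay, this single change is not shown to move the read-out beyond the scatter. Compound 3 sits at the same limit as compound 1, and the step between these two cannot be read. This comparison isolates one centre: the fact that compounds 2 and 3 differ only in the configuration as drawn

Going by these compounds, how far compound 3 truly lies from compound 2 stays open. So does whether an amine or a carboxylic acid on the shared core would lower the number.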